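Cytotoxicity Estimate for a Phenoxy Analog of Compound 1

The compounds below may be only part of what the source reports. "The series", "measured", "known", "first", "only" and "open" are said of these compounds alone.

Compound 1 `Cc1cc(C)cc(Cc2ccc3c(NCCCNCc4ccco4)ccnc3c2)c1` carries the highest of the three numbers recorded in an ADME assay on HepG2 cells (Homo sapiens) for cytotoxicity, read by luminescence, CellTiter-Glo and ATP content, with a stated time of 72 h (on this read-out lower numbers stand for an effect already at smaller amounts and higher numbers for an effect only at larger amounts of compound), where compound 1 gives 6270 nM. Compound 3 `COc1cccc(CNCCCNc2ccnc3cc(Cc4cc(C)cc(C)c4)ccc23)c1O` gives 2680 nM, and compound 2 `COc1ccc(F)cc1CNCCCNc1ccnc2cc(Cc3ccc(F)cc3Cl)ccc12` gives 2460 nM. Within the data shown here, the only single-change step measured, a 2.3-fold lower number from compound 1 to compound 3 (0.37 log units; beyond the scatter), comes from 2-hydroxy-3-methoxyphenyl in place of furan-2-yl on a saturated chain carbon bound to an amine nitrogen. Compound 4 `Clc1ccc(Oc2ccc3c(NCCCNCc4ccco4)ccnc3c2)cc1` differs from compound 1 elsewhere: 4-chlorophenoxy in place of 3,5-dimethylbenzyl on an aromatic carbon. Among the measured compounds shown here, no measured step touches an aromatic carbon of the shared core, so the step from compound 1 to compound 3 offers a sense of scale but not of direction. Compound 2 differs from compound 1 in two places at once, and its value cannot be split between them. With nothing to anchor the direction, compound 4 is expected to remain close to compound 1. The expected step is a 1.3-fold lower number from compound 1 to compound 4 (0.10 log units; within the scatter). Compound 4 is therefore estimated at 5000 nM, within a range from 1800 nM to 14000 nM.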

Compound 4, half-maximal effective concentration: 7800 nM
Beside the measured number, compound 4's estimate is 1.6-fold (0.19 log units) below it; measured number inside the range.
By their numbers in this assay, from the lowest: compounds 2 and 3 (each within the scatter of the next); then compounds 1 and 4 (each within the scatter of the next).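

At this aromatic carbon of the shared core, 4-chlorophenoxy in place of 3,5-dimethylbenzyl gives, in this assay, a 1.2-fold higher number from compound 1 to compound 4 (0.09 log units; within the scatter). Among these compounds, this is the first measured step at this position, and it shows that exchanging the whole group, with an oxygen and a chlorine entering, leaves compounds 1 and 4 indistinguishable on this read-out, whereas the one earlier step, at the other end of the molecule, is a 2.3-fold lower number from compound 1 to compound 3 (0.37 log units; beyond the scatter). Nothing measured here offers an explanation for this result.

The compounds shown leave open whether a carboxylic acid or a morpholine on this aromatic carbon would also stay within the scatter of compound 1. They also leave open whether 4-chlorophenoxy would behave the same way with 2-hydroxy-3-methoxyphenyl in place of furan-2-yl.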